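This account rests on a few compounds, and the source may have more. Where it says the series, first, only, none or still open, it means among the compounds named here.

Of the compounds shown here, three built on a shared core have been measured in a functional assay on cells (Cancer cell lines, Homo sapiens) for cytotoxicity, read by sulforhodamine B assay, with a stated time of 48 h; a higher number here means a weaker inhibitor of growth, a lower number a stronger inhibitor of growth. Compound 1 `COc1ccc(C2CC(c3ccc4ccccc4c3)=NN2C2=NC(=O)/C(=C3\C(=O)Nc4ccccc43)S2)cc1` gives 620 nM. Compound 2 `O=C1N=C(N2N=C(c3ccccc3)CC2c2ccc(Cl)cc2)S/C1=C1/C(=O)Nc2ccccc21` gives 230 nM. Compound 3 `COc1ccc(C2=NN(C3=NC(=O)/C(=C4\C(=O)Nc5ccccc54)S3)C(c3ccc(Cl)cc3)C2)cc1` gives 92400 nM, the highest of the three numbers; its nearest neighbour is compound 1 and its furthest is compound 2, both well beyond the scatter. For the measured compounds named here, the only single-point step among the measured compounds is a 400-fold higher number from compound 2 to compound 3 (2.60 log units; beyond the scatter).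

Compound 4 `O=C1N=C(N2N=C(c3ccc4ccccc4c3)CC2c2ccc(Cl)cc2)S/C1=C1/C(=O)Nc2ccccc21` has not yet been measured in this assay. It differs from compound 3 by naphthalen-2-yl in place of 4-methoxyphenyl on a carbon with a double bond to nitrogen. The measured step that bears on this change is the large rise from compound 2 to compound 3, since compound 4 removes the 4-methoxyphenyl that compound 3 carries on the carbon with a double bond to nitrogen and keeps the 4-chlorophenyl group shared with compound 2. Compound 1, which carries naphthalen-2-yl on that same carbon, gives 620 nM, so that group is compatible with a low number. Compound 4 is therefore expected to give about 300 nM, with a range from 100 nM to 1500 nM. The expected step of a 310-fold lower number from compound 3 to compound 4 (2.49 log units; beyond the scatter) is a large fall, roughly undoing the rise seen from compound 2 to compound 3.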

Compound 4, concentration for 50% growth inhibition: 460 nM
Beside the measured number, compound 4's estimate is 1.5-fold (0.19 log units) below it, within the range that was stated.
By their numbers in this assay, from the lowest: compounds 2, 4 and 1 (each within the scatter of the next, the first and the last beyond it); then compound 3.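

In this assay, with the 4-chlorophenyl group kept, replacing the 4-methoxyphenyl on the carbon with a double bond to nitrogen by naphthalen-2-yl gives a 200-fold lower number from compound 3 to compound 4 (2.30 log units; beyond the scatter), so the high number of compound 3 goes with the 4-methoxyphenyl there and not with the larger aromatic group as such. That position takes either one or two six-membered aromatic rings without a change beyond the scatter, as naphthalen-2-yl in place of phenyl gives a 2.0-fold higher number from compound 2 to compound 4 (0.30 log units; within the scatter), and the large rise seen in a 400-fold higher number from compound 2 to compound 3 (2.60 log units; beyond the scatter) therefore does not follow from size alone among these compounds. With naphthalen-2-yl in place, the step to chloro on the other aromatic ring, a 1.3-fold lower number from compound 1 to compound 4 (0.13 log units; within the scatter), also lies within the scatter, so methoxy on that ring shows no such penalty in this pair.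

Nothing at hand accounts for why the methoxy on the phenyl at the carbon with a double bond to nitrogen raises the number so sharply. On these data alone, whether a hydroxy group, an amine or a carboxylic acid on that same phenyl would bring a similar rise stays open, as does the effect of a saturated chain in place of the aromatic group.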